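Trifluoromethyl in Place of Bromo: Expectation for Compound 3

The compounds below may be only part of what the source reports. "The series", "measured", "known", "first", "only" and "open" are said of these compounds alone.

Compound 1 `O=C(Nc1ccc(S(=O)(=O)Nc2ccccc2)cc1)c1ccc(Br)cc1F` — 479 nM
Compound 2 `O=C(Nc1ccc(S(=O)(=O)Nc2ccccc2)cc1)c1ccc(Cl)cc1Cl` — 457 nM

Within the data shown here, in a functional assay on HEK293 cells for agonist activity at probable G-protein coupled receptor 27 (Homo sapiens), read by a luciferase reporter and beta-arrestin recruitment, with a stated time of 10 min (a lower number here means that less compound is needed, a higher number that more compound is needed for the effect), compound 1 gives 479 nM, the higher of the two numbers, yet the only measured step, a 1.0-fold lower number from compound 1 to compound 2 (0.02 log units; within the scatter), sits within the scatter. Compound 3 `O=C(Nc1ccc(S(=O)(=O)Nc2ccccc2)cc1)c1ccc(C(F)(F)F)cc1F` differs from compound 1 by trifluoromethyl in place of bromo on an aromatic carbon. Among the measured compounds shown here, the single measured step, which swaps the whole halogen pattern on that ring, bears on this change and was flat, so no shift beyond the scatter is expected in this assay. Compound 3 is therefore estimated at 500 nM, with a range of 200 nM to 1250 nM, an expected step of a 1.0-fold higher number from compound 1 to compound 3 (0.02 log units; within the scatter).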

Compound 3, half-maximal effective concentration: 363 nM
The estimate for compound 3 lay 1.4-fold (0.14 log units) above the measured number, within the range that was stated.
By their numbers in this assay, from the lowest: compounds 3, 2 and 1 (each within the scatter of the next).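

In this assay, trifluoromethyl in place of bromo gave a 1.3-fold lower number from compound 1 to compound 3 (0.12 log units; within the scatter), so at this aromatic carbon, para to a large group, four heavy atoms in place of one left the number within the scatter. Unlike the earlier step, which swapped the whole halogen pattern, this one changes a single group while the fluoro group stays. No measurement on hand explains this result. On these data alone, whether an amine or a carboxylic acid at this carbon would also leave the number unchanged remains open, as does the effect of replacing the fluoro group alone.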